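Removing a Hydroxy Group from a Biaryl Pyrazole Amide

This account rests on a few compounds, and the source may have more. Where it says the series, first, only, none or still open, it means among the compounds named here.

Four compounds share one core, a pyrazole carrying two amide groups and a doubly fluorinated phenyl ring that in turn bears a further aromatic ring. They were tested in a functional assay on A2058 cells (Homo sapiens) for antiproliferative activity, read by luminescence and CellTiter-Glo, with a stated time of 96 h; a higher number here means a weaker inhibitor, a lower number a stronger inhibitor. Compound 1 `COc1ccc(-c2ccc(F)c(C(=O)Nc3c[nH]nc3C(=O)Nc3ccc(F)cc3)c2F)cn1` carries a methoxy-substituted pyridine as the outer ring; in this assay compound 1 gives "not determined" (no result reported), so no result was reported for it. Compound 2 `O=C(Nc1ccc(F)cc1)c1n[nH]cc1NC(=O)c1c(F)ccc(-c2cccc(O)c2)c1F` carries a 3-hydroxyphenyl group there; in this assay compound 2 gives "not determined" (no result reported), so no result was reported for compound 2 either and its position on the numbers cannot be stated. Compound 3 `NC(=O)c1cccc(-c2ccc(F)c(C(=O)Nc3c[nH]nc3C(=O)Nc3ccc(F)cc3)c2F)c1` carries a carboxamide on the outer phenyl ring, and in this assay compound 3 gives 1990 nM.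

Compound 4 `O=C(Nc1ccc(F)cc1)c1n[nH]cc1NC(=O)c1c(F)ccc(-c2ccccc2)c1F` has not yet been measured. It differs from compound 2 in one place: hydrogen in place of hydroxy on an aromatic carbon. For the measured compounds named here, with no measured pair showing the weight of this change, the expected step in this assay cannot be drawn from the data; the only anchor is compound 3 at 1990 nM. Compound 4 is therefore estimated at 2500 nM, with a range from 500 nM to 12000 nM.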

Compound 4, half-maximal inhibitory concentration: 2370 nM
Beside the measured number, compound 4's estimate is 1.1-fold (0.02 log units) above it, and the stated range covers the measured number.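

In this assay, replacing the carbamoyl group on the outer ring with hydrogen gives a 1.2-fold higher number from compound 3 to compound 4 (0.08 log units; within the scatter), so this first measured pair shows that a carbamoyl group and a plain hydrogen at this place on the ring cannot be told apart in this read-out. As far as these compounds go, the change from 3-hydroxyphenyl to phenyl, however, cannot be read: compound 2 has no reported result, so the weight of the hydroxy group remains unknown. Nothing available explains why compound 3 and compound 4 read alike.

With only one readable step, the compounds shown leave open whether any group at this place can move the number beyond the scatter. A carboxylic acid or an amine on the same ring, for example, would test whether this insensitivity extends beyond the carbamoyl group.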